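A few compounds are considered here, and "the series" means these few. Any claim that something is new, unique, unknown or untested is made for them only; others in the source may bear on it.

Compound 1 `Cc1ccc(N2CCN(C(=O)Nc3ccc(C(C)C)cc3)CC2)nn1`: in an assay on HEK293 cells for inhibition of transient receptor potential cation channel subfamily V member 1 (Homo sapiens), read by FLIPR (on this read-out lower numbers stand for stronger inhibition and higher numbers for weaker inhibition), compound 1 gives only the limit > 10000 nM.
Compound 2 `CC(C)c1ccc(NC(=O)N2CCN(c3ccc(-c4ccccc4)nn3)CC2)cc1`: in this assay compound 2 gives only the limit > 10000 nM.

Both values sit at the limit of > 10000 nM in this assay, at which 2 of the 2 values shown sit, so compound 2 stands at the limit of this assay and not at a number. Within the data shown here, the one measured step, a step that the two limits leave unreadable from compound 1 to compound 2, is unreadable in size. Compound 3 `O=C(Nc1ccc(OC(F)(F)F)cc1)N1CCN(c2ccc(-c3ccccc3)nn2)CC1` differs from compound 2 by trifluoromethoxy in place of isopropyl on an aromatic carbon. No readable step bears on this change, so no direction of change in this assay is expected beyond the scatter. Compound 3 is therefore expected to remain near the limit, estimated at 10000 nM (range 2000 nM to 30000 nM). This expectation means a step of a number no higher from compound 2 to compound 3 (the limit leaves the size open).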

Compound 3, half-maximal inhibitory concentration: > 10000 nM
Compound 3 gave a limit, no number (the forecaster's own chance of this, stated with the estimate: 70%); the middle value lies on the limit itself.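

No step can be read from compound 2 to compound 3, because both stop at a limit and not at a number: the limit of > 10000 nM in this assay, at which 3 of the 3 values shown sit.

The compounds shown leave open what number any of compound 1, compound 2 and compound 3 would reach in this assay and whether trifluoromethoxy in place of isopropyl changes it at all.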